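Notes on two measured compounds and one proposed

This account rests on a few compounds, and the source may have more. Where it says the series, first, only, none or still open, it means among the compounds named here.

Measured so far:
- compound 1, `O=C(NC1CCN(CC2CC2)C1)c1cc(-c2ccc(NS(=O)(=O)c3cccc(Cl)c3Cl)cc2)nc2[nH]ncc12`, gives 1 nM in an assay for inhibition of serine/threonine-protein kinase Sgk1 (Homo sapiens), with stated times of 30 min and 60 min, in the presence of a further agent that is not named here; a lower number here means a stronger inhibitor, a higher number a weaker inhibitor
- compound 2, `CCOc1nc(-c2ccc(NS(=O)(=O)c3cc(Cl)ccc3F)cc2)nc2[nH]nc(C)c12`, gives 23 nM in this assay

Among the compounds with values here, compound 2 holds the higher of the two numbers so far; the gap to compound 1, its only neighbour, is well beyond the scatter. The two differ in several places at once, so nothing can be drawn from them about any single change.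

Compound 3, `Cc1n[nH]c2nc(-c3ccc(NS(=O)(=O)c4cc(Cl)ccc4F)cc3)nc(OCC3CNCCO3)c12`, has not been measured. It comes from compound 2 by one change: morpholin-2-yl in place of methyl on a saturated chain carbon bound to an oxygen on an aromatic ring. Within the data shown here, no measured pair shows this change on its own, so there is no step to lean on. Compound 1, with its basic ring on a chain, sits at 1 nM, but this is no guide to the present change, since compound 1 differs from compound 2 in more than one place.

The expectation for compound 3 is a modest step downward, a 2.3-fold lower number from compound 2 to compound 3 (0.36 log units; beyond the scatter), not firmly beyond the scatter. The estimate for compound 3 in this assay is 10 nM, within a range from 3 nM to 40 nM.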

Compound 3, half-maximal inhibitory concentration: 2 nM
Beside the measured number, compound 3's estimate is 5.0-fold (0.70 log units) above it; the measured number lies below the stated range.
By their numbers in this assay, from the lowest: compounds 1 and 3 (each within the scatter of the next); then compound 2.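

At the saturated chain carbon bound to an oxygen on an aromatic ring, this assay gives its first single-change reading: a 12-fold lower number from compound 2 to compound 3 (1.06 log units; beyond the scatter) when morpholin-2-yl takes the place of methyl. This position therefore accepts one six-membered non-aromatic ring with 2 hetero atoms, with 6 heavy atoms entering where 1 carbon leaves, and the number falls by a large step rather than rising. Nothing on hand accounts for the size of this step or ties it to any one part of the morpholin-2-yl group.

Still open, going by these compounds, is which part of the morpholin-2-yl group goes with the step: tetrahydropyran-2-yl, piperidin-2-yl or an open aminoethyl chain in the same place would set the ring nitrogen, the ring oxygen and the ring itself apart. Also open, on these data alone, is whether the same change gives a step of similar size on the core of compound 1, or with the ethoxy chain replaced by a longer chain carrying a dimethylamino group.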